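Swapping carboxy for sulfamoyl on a chalcone acid

The compounds below may be only part of what the source reports. "The series", "measured", "known", "first", "only" and "open" are said of these compounds alone.

Measured compounds:
- Compound 1, `CC(C)(C)CCOc1cccc(O)c1C(=O)/C=C/c1ccc(C(=O)O)cc1`: 2800 nM
- Compound 2, `O=C(/C=C/c1ccc(O)cc1)c1c(O)cccc1OCC1CCCC1`: 13000 nM

Of the two compounds measured in an assay on THP-1 cells for inhibition of nuclear factor NF-kappa-B complex (Homo sapiens), with stated times of 2 h and 16 h (a lower number here means a stronger inhibitor, a higher number a weaker inhibitor), compound 1 stands at the lowest number, with 2800 nM. Compound 2 gives 13000 nM in this assay, a gap that lies beyond the usual scatter of repeated measurements, so compound 1 is the stronger inhibitor of the pair.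

Compound 3, `CC(C)(C)CCOc1cccc(O)c1C(=O)/C=C/c1ccc(S(N)(=O)=O)cc1`, has not yet been measured. It is built from compound 1 by one change: sulfamoyl in place of carboxy on an aromatic carbon. Among the measured compounds shown here, no step between two measured compounds describes such an exchange, so the expectation rests on the structural change alone. The expected step from compound 1 to compound 3 is small, a 1.4-fold higher number from compound 1 to compound 3 (0.15 log units; within the scatter), leaning toward a slightly higher number, though it may well fall within the scatter. Compound 3 is therefore estimated at 4000 nM, with a range from 1500 nM to 12000 nM.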

Compound 3, half-maximal inhibitory concentration: 1200 nM
Estimate against measurement, compound 3: 3.3-fold (0.52 log units) above; the whole stated range lies above it.
By their numbers in this assay, from the lowest: compound 3; then compound 1; then compound 2.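

Sulfamoyl in place of carboxy on an aromatic carbon, para to a large group, gives the first direct reading at this position: in this assay, the exchange brings a 2.3-fold lower number from compound 1 to compound 3 (0.37 log units; beyond the scatter), a modest step that lies beyond the usual scatter. On the core of compound 1, then, a carboxy group at this position is not needed to reach this level of inhibition, and the sulfamoyl group does better. No measurement shown accounts for this step.

Still open, as far as these compounds go, is how a methylsulfonyl group, a tetrazole or a plain amine at the same position would compare with carboxy and sulfamoyl. Also open, from the compounds shown here alone, is whether sulfamoyl would bring a step of similar direction and size on a core carrying the ether chain of compound 2.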